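Aromatic methyl step carried to a second core

A few compounds are considered here, and "the series" means these few. Any claim that something is new, unique, unknown or untested is made for them only; others in the source may bear on it.

Compound 1 `N/C(=N\NC(=S)N1CCOCC1)c1ccccn1` and compound 2 `N/C(=N\NC(=S)N1CCCCC1)c1ccccn1` share one framework and differ only at the thiocarbonyl carbon (piperidin-1-yl in place of morpholin-4-yl on a thiocarbonyl carbon). In a functional assay on A-431 cells (Homo sapiens) for cytotoxicity, read by MTT assay, with a stated time of 72 h, tested at 1 uM (on this read-out higher numbers stand for more inhibition of growth at the one concentration tested and lower numbers for less inhibition of growth), compound 1 gives 29.2%, and compound 2 gives 24.4%; the step of a number 4.8 percentage points lower from compound 1 to compound 2 (within the scatter) stays within the scatter, so the two cores are treated as equivalent here. Going by the values given here, compound 3 `Cc1cccc(/C(N)=N/NC(=S)N2CCOCC2)n1` carries a methyl on the core of compound 1 (methyl in place of hydrogen on an aromatic carbon); in this assay compound 3 gives 47.2%, so a number 18 percentage points higher from compound 1 to compound 3 (beyond the scatter) is a modest gain and the only step beyond the scatter among the three measured compounds. Compound 4 `Cc1ccnc(/C(N)=N/NC(=S)N2CCCCC2)c1` applies the same kind of change to compound 2 (methyl in place of hydrogen on an aromatic carbon); the methyl sits meta to a large group in both cases, but in compound 3 it is next to the ring nitrogen, whereas in compound 4 it is opposite the ring nitrogen. One instance of this change is known, on one core and at one place, so the expectation is loose. Among the compounds with values here, compound 4 is expected to show a number 11.6 percentage points higher from compound 2 to compound 4 (beyond the scatter) in this assay, set somewhat below a number 18 percentage points higher from compound 1 to compound 3 (beyond the scatter) as the one known instance sits at a different place on the ring. Compound 4 is estimated at 36%, between 22% and 52%.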

Compound 4, percent growth inhibition at one concentration: 31.1%
Estimate against measurement, compound 4: 4.9 percentage points above; low and high end bracket the measured number.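

Methyl in place of hydrogen on an aromatic carbon, opposite the ring nitrogen, gives a number 6.7 percentage points higher from compound 2 to compound 4 (within the scatter) in this assay, so no effect of the methyl can be claimed on this core. Set against the earlier step, the change is not shown to differ between the two cores: the same change on two cores in this assay, a number 18 percentage points higher (beyond the scatter) from compound 1 to compound 3 and a number 6.7 percentage points higher (within the scatter) from compound 2 to compound 4, 11.3 percentage points apart, within the scatter of two such steps. Going by these compounds alone, this does not establish that the gain carries over, as there are only two instances and the core and the place of the methyl on the ring change together, so neither can be credited separately.

Going by these compounds, it remains open whether methyl at these two places on the ring would give matching steps on a single core, with morpholin-4-yl or piperidin-1-yl held fixed. Also open, on these data alone, is how other groups at the same ring carbon, such as ethyl, methoxy or an amine, would read out in this assay on either core.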